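Removing a Fluorine: What Cell Tolerance Should Show

The source may report more compounds than this note shows. Statements on the series, on what has been measured and on what is new or still open speak of the compounds shown alone.

Three measured compounds share a common frame joined through a flexible linker to an oxime-bearing fragment. Compound 1 `CCOC(=O)c1c(-c2ccc(OC)cc2)oc2ccc(OCCCCCN3C(=O)/C(=N\OC)c4cc(F)ccc43)cc12` and compound 3 `CCOC(=O)c1c(-c2ccc(OC)cc2)oc2ccc(OCCCCCN3C(=O)/C(=N\OC)c4ccccc43)cc12` differ in a single place: hydrogen in place of fluoro on an aromatic carbon. Compound 2 `CCO/N=C1\C(=O)N(CCCCOc2ccc3oc(-c4ccc(OC)cc4)c(C(=O)OCC)c3c2)c2ccc(F)cc21` has the same atoms as compound 1, joined differently; the difference between the two cores is not broken down here. The unmeasured compound 4 `CCO/N=C1\C(=O)N(CCCCOc2ccc3oc(-c4ccc(OC)cc4)c(C(=O)OCC)c3c2)c2ccccc21` stands to compound 2 exactly as compound 3 stands to compound 1: hydrogen in place of fluoro on an aromatic carbon, the same change at a place described in the same words.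

In an ADME assay on Vero cells (Chlorocebus sabaeus) for cytotoxicity, read by MTT assay, with a stated time of 72 h (a lower number here means that less compound is tolerated, a higher number that more compound is tolerated), compound 1 gives 32 ug/mL, compound 3 gives 32 ug/mL and compound 2 gives 32 ug/mL. Between the two compounds that differ only by this change, no change at the digits printed from compound 1 to compound 3 (within the scatter). All three measured values sit together within the usual scatter.

The expected step is no change at the digits printed from compound 2 to compound 4 (within the scatter), resting on the fact that no change at the digits printed from compound 1 to compound 3 (within the scatter). Compound 4 is therefore estimated at 32 ug/mL, most likely falling between 16 ug/mL and 64 ug/mL. The measured value will tell whether this holds.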

Compound 4, half-maximal cytotoxic concentration: 64 ug/mL
Compound 4: the middle estimate sits 2.0-fold (0.30 log units) below what was measured; the range from low to high includes it.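

Putting hydrogen in place of fluoro on the core of compound 2 gives a 2.0-fold higher number from compound 2 to compound 4 (0.30 log units; within the scatter) in this assay, so the small step seen on the first core also stays small on the second. Set side by side, the two steps agree as closely as repeated measurements can show: the same change on two cores in this assay, no change at the digits printed (within the scatter) from compound 1 to compound 3 and a 2.0-fold higher number (0.30 log units; within the scatter) from compound 2 to compound 4, 2.0-fold (0.30 log units) apart, within the scatter of two such steps. This means the change can be carried between these two cores in this cell tolerance test without a step that stands clear of the scatter, but it rests on one pair per core, and it does not show that the same would hold on any other core, in any other test, or that the fluoro group never matters.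

The compounds shown leave open what a different group on that same aromatic carbon, such as chloro, an amine or a carboxylic acid, would do to cell tolerance. They also leave open whether a longer chain in the linker would change the picture.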